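The source may hold more compounds than are shown below. What is called first, only, known or untested is meant among the compounds shown, and "the series" means these compounds.

Compound 1, `CCCCC[Se]c1nc([Se]CCCCC)c2ccccc2n1`, gives 95100 nM in a functional assay on MCF7 cells (Homo sapiens) for cytotoxicity, read by MTT assay, with a stated time of 72 h; a lower number here means a stronger inhibitor of growth, a higher number a weaker inhibitor of growth.
Compound 2, `CCCCC[Se]c1nc(NCc2ccccc2)c2ccccc2n1`, gives 47100 nM in this assay.
Compound 3, `Nc1nc([SeH])nc2ccccc12`, gives only a limit of the assay, > 100000 nM, in this assay.

Compound 3 thus stands apart from the other two: its result is a limit, the line (the limit of > 100000 nM in this assay, at which 1 of the 3 values shown sits), so no number is known for it, whereas compound 1 and compound 2 each give a measurable value. Compound 4, `CCCCC[Se]c1nc(N)c2ccccc2n1`, differs from compound 3 in one place: pentyl in place of hydrogen on a selenium. Among the measured compounds shown here, no measured step follows this same change. For the measured compounds named here, the only measured step, a 2.0-fold lower number from compound 1 to compound 2 (0.31 log units; beyond the scatter), concerns a different position and gives no direct guidance here. What the data do show is that both compounds carrying the pentyl group on selenium, compound 1 and compound 2, return measurable numbers, while compound 3, without it, does not. On that basis compound 4 is expected to fall into the measurable range, with an estimated step of an at least 1.4-fold lower number from compound 3 to compound 4 (0.15 log units; that floor lies within the scatter). The estimate for compound 4 in this assay is 70000 nM, within a range of 30000 nM to 150000 nM.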

Compound 4, concentration for total growth inhibition: 59500 nM
Estimate against measurement, compound 4: 1.2-fold (0.07 log units) above, within the range that was stated.
By their numbers in this assay, from the lowest: compounds 2, 4 and 1 (each within the scatter of the next, the first and the last beyond it). At a limit, above all of these: compound 3.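

Pentyl in place of hydrogen on a selenium gives a measured number where there was only a limit, with an at least 1.6-fold lower number from compound 3 to compound 4 (0.22 log units; that floor lies within the scatter), so the true size of this change stays unknown. Compound 3 remains a limit: the limit of > 100000 nM in this assay, at which 1 of the 4 values shown sits.

At the other place on the core, hydrogen in place of benzyl on the nitrogen gives a 1.3-fold higher number from compound 2 to compound 4 (0.10 log units; within the scatter), and one nitrogen atom in place of the selenium-bearing group gives a 1.6-fold lower number from compound 1 to compound 4 (0.20 log units; within the scatter), so with pentyl on the selenium, a measurable number in this assay does not depend on either larger group.

The compounds shown leave open how a methyl or a longer chain on the selenium would compare with pentyl. They also leave open what a carboxylic acid or a phenyl ring would do in that place.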